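The source may report more compounds than this note shows. Statements on the series, on what has been measured and on what is new or still open speak of the compounds shown alone.

Compound 1 `CC1(C)CC(NC(=S)Nc2cccc(C#N)c2)c2cc(Br)ccc2O1` is a thiourea that carries a 3-cyanophenyl group on one of its nitrogens. In a functional assay on U-373MG ATCC cells (Homo sapiens) for inhibition, read by MTT assay, with a stated time of 72 h (on this read-out lower numbers stand for stronger inhibition and higher numbers for weaker inhibition), compound 1 gives 6000 nM. Among the compounds with values here, the only other measured compound, compound 2 `O=[N+]([O-])c1cccc(NC(=S)NCc2cccc(Cl)c2)c1`, a differently built thiourea, gives in this assay a value of 32000 nM. Compound 1 thus holds the lower of the two numbers, and the gap to compound 2 lies beyond the usual scatter.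

Compound 3 `CC1(C)CC(NC(=S)Nc2ccc(C#N)cc2)c2cc(Br)ccc2O1` shares the core of compound 1 and differs from it in one place (4-cyanophenyl in place of 3-cyanophenyl on an amide-type nitrogen). Within the data shown here, no pair of measured compounds shows what such a change does in this assay, so there is nothing to suggest a move in either direction. The step expected is no change at the digits printed from compound 1 to compound 3 (within the scatter), that is, none beyond the scatter. Compound 3 is therefore expected to give about 6000 nM, with a likely range from 2000 nM to 20000 nM.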

Compound 3, half-maximal inhibitory concentration: 22000 nM
Compound 3: middle estimate off by 3.7-fold (0.56 log units), on the low side; the whole stated range lies below it.
By their numbers in this assay, from the lowest: compound 1; then compounds 3 and 2 (each within the scatter of the next).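

Keeping the same atoms and changing only where the nitrile sits on the phenyl ring is enough to shift the result in this assay: placing 4-cyanophenyl instead of 3-cyanophenyl on the amide-type nitrogen gives a 3.7-fold higher number from compound 1 to compound 3 (0.56 log units; beyond the scatter) and so moves the compound toward weaker inhibition. This position therefore responds to the arrangement of the ring and not only to which atoms it carries, and of these two arrangements the 3-cyanophenyl form holds the lower number. No measurement bears on why the two arrangements differ.

Going by these compounds, whether the nitrile itself is needed remains open, since a plain phenyl ring offers no comparison here. It is equally unknown how an amine or a carboxylic acid would fare in its place on this ring.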